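This account rests on a few compounds, and the source may have more. Where it says the series, first, only, none or still open, it means among the compounds named here.

Compound 1 has the structure `Clc1ccc(Cc2nn3cc(-c4ccc(Cl)cc4Cl)nc3s2)cc1`. In an ADME assay on CCRF-CEM cells (Homo sapiens) for cytotoxicity, with a stated time of 72 h (on this read-out higher numbers stand for weaker inhibition and lower numbers for stronger inhibition), compound 1 gives > 250000 nM, which is a limit of the assay and not a number. Compound 2 has the structure `Clc1ccc(Cc2nn3cc(-c4ccccc4)nc3s2)cc1`. In this assay compound 2 gives > 250000 nM, again a limit rather than a number. Compound 3 has the structure `O=[N+]([O-])c1ccc(-c2cn3nc(Cc4ccc(Cl)cc4)sc3n2)cc1`. In this assay compound 3 gives > 250000 nM, also a limit and not a number.

Compound 3 therefore stands where every measured compound in this set stands: at the limit, with no number to compare. The two steps among the measured compounds, a step that the two limits leave unreadable from compound 1 to compound 2 and a step that the two limits leave unreadable from compound 2 to compound 3, cannot be read as steps of any size, because the limit of > 250000 nM in this assay, at which 3 of the 3 values shown sit, shows that every value sits at the limit itself.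

The next compound, compound 4 with the structure `O=[N+]([O-])c1ccc(-c2nc3sc(Cc4ccc(Cl)cc4)nn3c2Br)cc1`, differs from compound 3 by one change: bromo in place of hydrogen on an aromatic carbon. For the measured compounds named here, no measured step bears on this change, and the measured steps that exist are themselves unreadable. The expectation for this assay is therefore no readable step beyond the scatter, with the estimated step being a number no higher from compound 3 to compound 4 (the limit leaves the size open). Compound 4 is expected to give about 250000 nM, with a range from 30000 nM to 2500000 nM, and most likely only a limit again.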

Compound 4, half-maximal inhibitory concentration: 73000 nM
Compound 4: the middle estimate sits 3.4-fold (0.53 log units) above what was measured, and the stated range covers the measured number.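

Putting bromo in place of hydrogen on an aromatic carbon of the five-membered ring gives, in this assay, an at least 3.4-fold lower number from compound 3 to compound 4 (0.53 log units; beyond the scatter), and a lower number here stands for stronger inhibition. The earlier steps cannot be read, so this carbon, next to the ring nitrogen, is the only place among the compounds shown where a change brings a number out of the limit, and compound 4 alone carries a measured value: the limit of > 250000 nM in this assay, at which 3 of the 4 values shown sit. From the compounds shown here alone, the change is small, a single bromine atom with no ring and no net charge, yet it is enough to make the effect on these cells measurable, although the size of the step stays open at its upper end, as compound 3 has only a limit to start from.

The compounds shown leave open whether bromo at this carbon does the same without the nitro group, on the phenyl or 2,4-dichlorophenyl compounds, as it was read only on the nitro compound. They also leave open what another group at this carbon, such as a methyl group or an amine, would do, and why bromo has this effect.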